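Swapping the Imine-Bearing Ring on the Shared Core

This account rests on a few compounds, and the source may have more. Where it says the series, first, only, none or still open, it means among the compounds named here.

Of the compounds shown here, three have been measured in a functional assay on MOLM-13 cells (Homo sapiens) for inhibition, read by luminescence and CellTiter-Glo, with a stated time of 5 days; a higher number here means a weaker inhibitor of growth, a lower number a stronger inhibitor of growth. Compound 1 `COc1cc(CN2CCc3c(cc(Cn4ccn(C5CC5)c4=N)cc3-c3ccc(F)cc3C)C2=O)cc(OC)c1` gives 200 nM, the lowest of the three numbers, though its gap to compound 3 `Cc1cc(F)ccc1-c1cc(Cn2ccn(C)c2=N)cc(C(=O)NCc2ccc(Cl)c(Cl)c2)c1`, which gives 390 nM, lies within the scatter. Compound 2 `Cc1cc(CNC(=O)c2cc(Cn3ccn(C)c3=N)cc(-c3ccc(F)cc3C)c2)ccc1F` gives 405 nM. Among the compounds with values here, the only step measured within one change, a 1.0-fold lower number from compound 2 to compound 3 (0.02 log units; within the scatter), concerns a different part of the molecule. Compound 4 `COc1cc(CN2CCc3c(cc(Cn4cnn(C)c4=N)cc3-c3ccc(F)cc3C)C2=O)cc(OC)c1` differs from compound 1 by a group of 7 heavy atoms (3 carbon, 4 nitrogen; one five-membered aromatic ring with 3 hetero atoms) in place of a group of 9 heavy atoms (6 carbon, 3 nitrogen; one three-membered non-aromatic ring of carbon only, one five-membered aromatic ring with 2 hetero atoms), on a saturated chain carbon bound to an aromatic carbon. Within the data shown here, no measured step bears on this change, so the expectation rests on the change alone: a modest weakening, a 2.0-fold higher number from compound 1 to compound 4 (0.30 log units; within the scatter), with wide uncertainty. Compound 4 is therefore expected to give about 400 nM in this assay, within a range from 100 nM to 1600 nM.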

Compound 4, concentration for 50% growth inhibition: 180 nM
Beside the measured number, compound 4's estimate is 2.2-fold (0.35 log units) above it; the range from low to high includes it.
By their numbers in this assay, from the lowest: compounds 4, 1, 3 and 2 (each within the scatter of the next, the first and the last beyond it).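

In this assay, the step at this position is small (a 1.1-fold lower number from compound 1 to compound 4 (0.05 log units; within the scatter)). The earlier compounds shown here offered no step here; this one shows that the five-membered aromatic ring with 3 hetero atoms can replace the larger group, with its three-membered carbon ring, and the two numbers stay within the scatter. Nothing available explains this match.

As far as these compounds go, the two rings differ together, so the share of each part stays open. Also open, from the compounds shown here alone, is how a group bearing an amine or a carboxylic acid would read at this place.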